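This account rests on a few compounds, and the source may have more. Where it says the series, first, only, none or still open, it means among the compounds named here.

Compound 1 `CCCNC(=O)[C@@H]1CN[C@H](C(=O)N2CCC[C@H]2C#N)C1` gives 59% in an assay on the whole organism (plasma, strain Sprague-Dawley) for inhibition of Dipeptidyl peptidase 4 (Rattus norvegicus), with a stated time of 6 h, at a dose of 1 mg/kg by the oral route (a higher number here means more inhibition at the dose given (going by the name of the read-out), a lower number less inhibition), the smallest of the three numbers at hand, though its gap to compound 3 lies within the scatter. Compound 2 `N#C[C@@H]1CCCN1C(=O)[C@@H]1C[C@H](C(=O)N2CCCCC2)CN1` gives 84% and compound 3 `N#C[C@@H]1CCCN1C(=O)[C@@H]1C[C@H](C(=O)N2CCCCCC2)CN1` gives 68%. The step of a number 25 percentage points higher from compound 1 to compound 2 (beyond the scatter) lies beyond the scatter, whereas a number 9 percentage points higher from compound 1 to compound 3 (within the scatter) does not, and a number 16 percentage points lower from compound 2 to compound 3 (beyond the scatter) lies beyond it. Compound 4 `N#C[C@@H]1CCCN1C(=O)[C@@H]1CCCN1` differs from compound 1 by hydrogen in place of propylcarbamoyl on a saturated ring carbon. For the measured compounds named here, none of the measured steps removes this group; the two steps that start from compound 1 only exchange the propylamino part, so nothing measured tells what its loss does. The account therefore expects a fall, probably beyond the scatter, a number 24 percentage points lower from compound 1 to compound 4 (beyond the scatter), with wide uncertainty. Compound 4 is estimated at 35%, between 10% and 62%.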

Compound 4, a percentage reported as inhibition, in the whole organism at one dose (the size of the read-out at that dose, not a potency): 20%
For compound 4 the middle estimate is 15 percentage points above the measured one; measured number inside the range.
By their numbers in this assay, from the lowest: compound 4; then compounds 1 and 3 (each within the scatter of the next); then compound 2.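

With hydrogen in place of propylcarbamoyl on this saturated ring carbon, this assay shows a number 39 percentage points lower from compound 1 to compound 4 (beyond the scatter), a large fall. The earlier compounds shown here only exchanged the amine part on the carbonyl, whereas this step shows that losing the whole group matters at this position, with compound 4 lowest of the four. No measurement at hand accounts for this fall. Still open, going by these compounds, is whether the carbonyl alone would keep the number, as a carboxylic acid or a plain propyl chain on this carbon might test. Also open, on these data alone, is how a primary amide would compare.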